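Iodo for Isopropyl in an Aryl Sulfonate Urea Series

This account rests on a few compounds, and the source may have more. Where it says the series, first, only, none or still open, it means among the compounds named here.

The measured compounds, all in a functional assay on M21 cells (Homo sapiens) for antiproliferative activity, read by sulforhodamine B assay, with a stated time of 48 h; a lower number here means a stronger inhibitor, a higher number a weaker inhibitor:
compound 1 `CCCNC(=O)Nc1ccc(S(=O)(=O)Oc2ccccc2C(C)C)cc1` gives 5100 nM
compound 2 `CCCNC(=O)Nc1ccc(S(=O)(=O)Oc2ccccc2I)cc1` gives 5400 nM
compound 3 `CC(C)c1ccccc1OS(=O)(=O)c1ccc(NC(=O)NCC2CCCC2)cc1` gives 6600 nM

The change from compound 1 to compound 2 is iodo in place of isopropyl on an aromatic carbon and made a 1.1-fold higher number from compound 1 to compound 2 (0.02 log units; within the scatter) in this assay. Compound 3 differs from compound 1 by cyclopentyl in place of ethyl on a saturated chain carbon bound to an amide-type nitrogen, with a 1.3-fold higher number from compound 1 to compound 3 (0.11 log units; within the scatter). Compound 4 `O=C(NCC1CCCC1)Nc1ccc(S(=O)(=O)Oc2ccccc2I)cc1` carries the same change on the core of compound 3: iodo in place of isopropyl on an aromatic carbon. The place matches the earlier one word for word, so it is the same change. Within the data shown here, for compound 4 a step of a 1.1-fold higher number from compound 3 to compound 4 (0.03 log units; within the scatter) is expected, resting on the single earlier example, where the step from compound 1 to compound 2 stayed within the scatter. Compound 4 is therefore estimated at 7000 nM, between 3500 nM and 14000 nM.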

Compound 4, half-maximal inhibitory concentration: 7600 nM
Beside the measured number, compound 4's estimate is 1.1-fold (0.04 log units) below it, and the stated range covers the measured number.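

Iodo in place of isopropyl on an aromatic carbon gave, in this assay, a 1.2-fold higher number from compound 3 to compound 4 (0.06 log units; within the scatter), and the step carried over to the second core with no gap that can be read: the same change on two cores in this assay, a 1.1-fold higher number (0.02 log units; within the scatter) from compound 1 to compound 2 and a 1.2-fold higher number (0.06 log units; within the scatter) from compound 3 to compound 4, 1.1-fold (0.04 log units) apart, within the scatter of two such steps

Cyclopentyl in place of ethyl gave a 1.4-fold higher number from compound 2 to compound 4 (0.15 log units; within the scatter), and this step also carried over: the same change on two cores in this assay, a 1.3-fold higher number (0.11 log units; within the scatter) from compound 1 to compound 3 and a 1.4-fold higher number (0.15 log units; within the scatter) from compound 2 to compound 4, 1.1-fold (0.04 log units) apart, within the scatter of two such steps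

Among these compounds, since every one of these steps lies within the scatter, the series shows only that both changes stay small on two cores; it does not show that a larger step would carry over in the same way, or how either change would act on a third core.

The compounds shown leave open what a bromo, a methoxy or an amine would give on that aromatic carbon. They also leave open whether a longer chain or a carboxylic acid on the amide-type nitrogen side would move the number beyond the scatter.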